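The source may hold more compounds than are shown below. What is called first, only, known or untested is meant among the compounds shown, and "the series" means these compounds.

Series notes, cytotoxicity. In a functional assay on HT-29 cells (Homo sapiens) for cytotoxicity, read by MTT assay, with a stated time of 72 h (on this read-out lower numbers stand for stronger inhibition and higher numbers for weaker inhibition), compound 1 `CN(C)CCn1cnnc1-c1cc(Oc2ccc(NC(=O)N/N=C/c3c[nH]c4ccccc34)cc2F)ccn1` gives 1300 nM. Compound 2 `COc1ccc(OC)c(/C=N/NC(=O)Nc2ccc(Oc3ccnc(-c4nncn4CCN(C)C)c3)c(F)c2)c1` gives 2070 nM in this assay, and compound 3 `CN(C)CCn1cnnc1-c1cc(Oc2ccc(NC(=O)N/N=C/c3ccc(F)cc3F)cc2F)ccn1` gives 960 nM. On these three numbers compound 1 sits second highest: nearest is compound 3, with a 1.4-fold lower number from compound 1 to compound 3 (0.13 log units; within the scatter); furthest is compound 2, with a 1.6-fold higher number from compound 1 to compound 2 (0.20 log units; within the scatter). Between the two replacements themselves the run is a 2.2-fold lower number from compound 2 to compound 3 (0.33 log units; beyond the scatter).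

Compound 4 `CN(C)CCn1cnnc1-c1cc(Oc2ccc(NC(=O)N/N=C/c3ccc(O)c(O)c3)cc2F)ccn1` has not yet been measured in this assay. It differs from compound 1 in a single place: 3,4-dihydroxyphenyl in place of 1H-indol-3-yl on a carbon with a double bond to nitrogen.

For the measured compounds named here, the steps that bear on this change are the two already made at the same carbon, from compound 1 to compound 2 and from compound 1 to compound 3, since each exchanges the 1H-indol-3-yl for a six-membered aromatic ring of carbon only; both stayed within the scatter. Only the pairing of compound 2 with compound 3 reached a modest size. Going by the values given here, no prior step places the 3,4-dihydroxyphenyl there, so the expectation rests on the tolerance seen so far at this carbon. For compound 4 the expected step in this assay is no change at the digits printed from compound 1 to compound 4 (within the scatter), that is, none beyond the scatter. Compound 4 is estimated at 1300 nM, with a range of 600 nM to 2800 nM.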

Compound 4, half-maximal inhibitory concentration: 1890 nM
The estimate for compound 4 lay 1.5-fold (0.16 log units) below the measured number, within the range that was stated.
By their numbers in this assay, from the lowest: compounds 3, 1, 4 and 2 (each within the scatter of the next, the first and the last beyond it).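

Working notes on the 3,4-dihydroxyphenyl change: in this assay, all three new steps at this carbon stay within the scatter: a 1.5-fold higher number from compound 1 to compound 4 (0.16 log units; within the scatter), a 2.0-fold higher number from compound 3 to compound 4 (0.29 log units; within the scatter) and a 1.1-fold lower number from compound 2 to compound 4 (0.04 log units; within the scatter). For the compounds shown here, the tolerance seen with 2,4-difluorophenyl and 2,5-dimethoxyphenyl in place of 1H-indol-3-yl therefore extends to a group with 2 hydrogen-bond donors and 2 hydrogen-bond acceptors, where 1H-indol-3-yl has 1 hydrogen-bond donor and 0 hydrogen-bond acceptors, and the only step beyond the scatter in the set remains that between compound 2 and compound 3. No supporting data accompany these numbers that could account for the result.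

The compounds shown leave open whether a single hydroxyl, a carboxylic acid or an aminomethyl group on the phenyl ring would also stay within the scatter of compound 1. They also leave open whether this tolerance extends beyond aromatic rings to a cyclohexyl or piperidinyl group on the carbon with a double bond to nitrogen.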